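The source may report more compounds than this note shows. Statements on the series, on what has been measured and on what is new or still open speak of the compounds shown alone.

Compound 1 `CN1CCC(C(=O)N2Cc3c(NC(=O)C4CCC4)n[nH]c3C2(C)C)CC1`, compound 2 `CN1CCC(C(=O)N2Cc3c(NC(=O)c4ccco4)n[nH]c3C2(C)C)CC1` and compound 3 `CN1CCC(C(=O)N2Cc3c(NC(=O)c4cccs4)n[nH]c3C2(C)C)CC1` share one core and differ only in the group on the carbonyl carbon. In a physicochemical assay for solubility, at pH 7 (a lower number here means a less soluble compound, a higher number a more soluble compound), compound 1 is reported at the limit > 225000 nM. Compound 2 likewise stands at the limit > 225000 nM. Among the compounds with values here, compound 3 gives 155000 nM, the only number of the three, the other two resting at the limit of > 225000 nM in this assay, at which 2 of the 3 values shown sit. The steps of an at least 1.4-fold lower number from compound 1 to compound 3 (0.16 log units; that floor lies within the scatter) and an at least 1.4-fold lower number from compound 2 to compound 3 (0.16 log units; that floor lies within the scatter) lead to it, each only a floor within the scatter. Compound 4 `CN1CCC(C(=O)N2Cc3c(NC(=O)c4ccc(Cl)cc4)n[nH]c3C2(C)C)CC1` carries 4-chlorophenyl in place of thiophen-2-yl on a carbonyl carbon. Within the data shown here, no measured step covers this change, so one expects at most a modest lowering, a 1.6-fold lower number from compound 3 to compound 4 (0.19 log units; within the scatter). Compound 4 is therefore estimated at 100000 nM, within 40000 nM to 225000 nM.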

Compound 4, solubility: > 225000 nM
Compound 4: a limit, no number; the forecaster's own chance of this, stated with the estimate: 15%; middle value at least 2.2-fold (0.35 log units) away from the limit.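

In this assay the exchange of thiophen-2-yl for 4-chlorophenyl on the carbonyl carbon gives an at least 1.4-fold higher number from compound 3 to compound 4 (0.16 log units; that floor lies within the scatter) and so shows that this position can carry a six-membered aromatic ring of carbon only without the reading falling below the limit. The steps from compound 1 and from compound 2 to compound 4 join two limits and cannot be read. Within the data shown here, compound 3 stays the only compound with a number, the others sharing one ceiling: the limit of > 225000 nM in this assay, at which 3 of the 4 values shown sit.

Any order among compound 1, compound 2 and compound 4 remains open. So does whether an amine or a carboxylic acid on this carbonyl carbon would give a number.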